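The compounds below may be only part of what the source reports. "The series", "measured", "known", "first", "only" and "open" are said of these compounds alone.

Measured compounds:
compound 1 `CCC1(CCCCN2CCN(c3ccc(F)cc3)CC2)C(=O)Nc2ccccc21` — < 1 mg/kg
compound 2 `CCC1(CCCCN2CCN(c3ccc(F)c(Cl)c3)CC2)C(=O)Nc2ccccc21` — "not determined" (no result reported)
compound 3 `CCC1(CCCCN2CCN(c3ccc(OC)cc3)CC2)C(=O)Nc2ccccc21` — "not determined" (no result reported)

All three share one core and differ only in the group on the outer aromatic ring. In a functional assay on the whole organism (strain NMRI) with Mus musculus as the target, with a stated time of 5 min (on this read-out lower numbers stand for an effect already at smaller amounts and higher numbers for an effect only at larger amounts of compound), compound 1 gives < 1 mg/kg, which is a limit of the assay rather than a number. Within the data shown here, for compound 2 and compound 3 this assay reports no result, so compound 3 stands without a number of its own: the only entry with any value is the limit (the limit of < 1 mg/kg in this assay, at which 1 of the 3 values shown sits), and the other entry is also empty.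

Compound 4 `CCC1(CCCCN2CCN(c3ccc(Cl)cc3)CC2)C(=O)Nc2ccccc21` is not yet measured. It differs from compound 3 by chloro in place of methoxy on an aromatic carbon. Because compound 1 reached the limit of < 1 mg/kg in this assay, at which 1 of the 3 values shown sits, with a small halogen at that same position, compound 4, carrying another halogen there, is expected to behave much like it in this assay, with no step beyond the scatter between them. The estimate for compound 4 in this assay is 1 mg/kg, between 0.3 mg/kg and 5 mg/kg.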

Compound 4, minimum effective dose: > 10 mg/kg
Compound 4 was reported as a limit (the forecaster's own chance of this, stated with the estimate: 50%); middle value at least 10-fold (1.00 log units) from the limit.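

In this assay, this aromatic carbon, para to a large group, does not treat its two halogens alike: chloro in place of fluoro gives an at least 10-fold higher number from compound 1 to compound 4 (1.00 log units; beyond the scatter). Until now only compound 1 had any reading, so nothing showed that the position responds at all, and exchanging one halogen for another now proves enough to move the result beyond the usual scatter. From the compounds shown here alone, compound 1 and compound 4 both sit at limits of the assay rather than at numbers, so the true size of the gap stays unknown.

Steps to compound 2 and compound 3 cannot be read, as neither has a reported result. The compounds shown also leave open how a bromo, methyl or amino group at this same position would behave, and why chloro differs from fluoro here.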